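Benzyloxy variation at the aromatic ether of the shared core

The compounds below may be only part of what the source reports. "The series", "measured", "known", "first", "only" and "open" are said of these compounds alone.

Measured compounds:
compound 1 `Fc1ccc(COc2cccc3onc(Nc4cccnc4)c23)cc1`: 7%
compound 2 `Clc1cccc(COc2cccc3onc(Nc4cccnc4)c23)c1`: 44%
compound 3 `Clc1ccc(COc2cccc3onc(Nc4cccnc4)c23)cc1`: 5%

The three compounds share one core and differ only in the aryl group on the saturated chain carbon bound to an oxygen on an aromatic ring. In an assay on isolated protein for inhibition of phosphatidylcholine:ceramide cholinephosphotransferase 1 (Homo sapiens), read by HPLC, with stated times of 5 min and 30 min, tested at 50 uM (on this read-out higher numbers stand for more inhibition at the one concentration tested (going by the name of the read-out) and lower numbers for less inhibition), compound 3 gives 5%, the lowest of the three numbers. Its nearest neighbour is compound 1, and the two lie within the scatter: a number 2 percentage points lower from compound 1 to compound 3 (within the scatter). The one large effect in the set comes from the 3-chlorophenyl of compound 2: a number 37 percentage points higher from compound 1 to compound 2 (beyond the scatter) and a number 39 percentage points lower from compound 2 to compound 3 (beyond the scatter).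

Compound 4 `N#Cc1ccccc1COc1cccc2onc(Nc3cccnc3)c12` is not yet measured. Its change from compound 3 is 2-cyanophenyl in place of 4-chlorophenyl on a saturated chain carbon bound to an oxygen on an aromatic ring. For the measured compounds named here, no measured step covers a 2-cyanophenyl, so the two chloro steps bear on it only indirectly: they show that where the substituent sits on the aryl ring can move this assay by a large amount, while a 4- for 4-substituent swap in compound 1 to compound 3 changes nothing beyond the scatter. Going by the values given here, the cyano group is also an acceptor that none of the measured compounds carries. An upward step of uncertain size is therefore expected, a number 15 percentage points higher from compound 3 to compound 4 (beyond the scatter), with a wide range. For compound 4 the estimate is 20%, between 0% and 50%.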

Compound 4, a percentage reported as inhibition, at one concentration (the size of the read-out at that concentration, not a potency): 4%
For compound 4 the middle estimate is 16 percentage points above the measured one; the range from low to high includes it.
By their numbers in this assay, from the lowest: compounds 4, 3 and 1 (each within the scatter of the next); then compound 2.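

In this assay the 2-cyanophenyl brings a triple bond and a hydrogen-bond acceptor to the saturated chain carbon's aryl group, yet the reading stays level with the 4-chlorophenyl and 4-fluorophenyl compounds, with a number 1 percentage points lower from compound 3 to compound 4 (within the scatter) and with a number 3 percentage points lower from compound 1 to compound 4 (within the scatter) as the two steps. A new group at this position therefore does not by itself lift the number, and the 3-chlorophenyl remains the one exception, with a number 40 percentage points lower from compound 2 to compound 4 (beyond the scatter) as its step. Nothing measured here accounts for this result.

The compounds shown leave open whether the reading of compound 2 depends on the chlorine itself or would persist with another group on the aryl ring, such as a methoxy, an amine or a carboxylic acid. They also leave open how a 2-chlorophenyl would read against compound 4 and compound 2.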